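Working notes: pyridin-2-yl in place of pyridazin-3-yl

The source may report more compounds than this note shows. Statements on the series, on what has been measured and on what is new or still open speak of the compounds shown alone.

compound 1 `Cc1nnc(N2CCC(C(=O)N3N=CC[C@H]3c3ccccc3)CC2)o1`: 3.3 h
compound 2 `O=C(C1CCN(c2cccnn2)CC1)N1N=CC[C@H]1c1ccccc1`: 2.32 h

Within the data shown here, in an ADME assay on cells (Hepatocyte, Homo sapiens) for metabolic stability (a lower number here means that the compound disappears faster, a higher number that the compound lasts longer), compound 2 stands at 2.32 h, within the scatter of the only other value. Compound 3 `O=C(C1CCN(c2ccccn2)CC1)N1N=CC[C@H]1c1ccccc1` has pyridin-2-yl in place of pyridazin-3-yl on an amine nitrogen in a ring. Among the measured compounds shown here, one measured step bears on this place: a 1.4-fold lower number from compound 1 to compound 2 (0.15 log units; within the scatter). On that single step, no change beyond the scatter is expected in this assay. The expected step is a 1.1-fold lower number from compound 2 to compound 3 (0.04 log units; within the scatter). The estimated value for compound 3 is 2.1 h with a range from 1.1 h to 3.9 h.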

Compound 3, half-life: > 3.11 h
Compound 3: a limit, no number; the forecaster's own chance of this, stated with the estimate: 3%; middle value at least 1.4-fold (0.17 log units) away from the limit.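

In this assay, compound 3 gives > 3.11 h, a limit of the assay and not a number. The change from pyridazin-3-yl to pyridin-2-yl on an amine nitrogen in a ring gives an at least 1.3-fold higher number from compound 2 to compound 3 (0.12 log units; that floor lies within the scatter), so the floor alone establishes no gain at this position. The step from compound 1 to compound 3 cannot be read. Going by these compounds, whether phenyl or pyrimidin-2-yl on the same amine nitrogen would behave like pyridin-2-yl stays open. The full size of the step from pyridazin-3-yl also stays open because the result for compound 3 is a limit: the limit of > 3.11 h in this assay, at which 1 of the 3 values shown sits.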